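Swapping nitro for propanoyl on compound 3

The compounds below may be only part of what the source reports. "The series", "measured", "known", "first", "only" and "open" are said of these compounds alone.

Values in a functional assay on the whole organism (brain) with Mus musculus as the target; a lower number here means that less compound is needed, a higher number that more compound is needed for the effect:
Compound 1 `O=[N+]([O-])c1ccc(SCCc2c[nH]cn2)nc1`: 2.6 mg/kg
Compound 2 `O=[N+]([O-])c1ccc(CSCc2c[nH]cn2)cc1`: > 10 mg/kg (a limit of the assay, not a number)
Compound 3 `O=[N+]([O-])c1ccc(OCCc2c[nH]cn2)cc1`: 0.66 mg/kg

Of the two true numbers, compound 3 has the lower one, and its gap to compound 1 lies beyond the usual scatter. Compound 4 `CCC(=O)c1ccc(OCCc2c[nH]cn2)cc1` carries propanoyl in place of nitro on an aromatic carbon. Going by the values given here, no two measured compounds differ in only one place, which leaves this swap without a direct precedent. A modest rise in the number, needing somewhat more compound, is the expectation, and it may not clear the scatter. The estimated size is a 1.5-fold higher number from compound 3 to compound 4 (0.18 log units; within the scatter). For compound 4 the expected value is 1 mg/kg, with an estimated range of 0.25 mg/kg to 4 mg/kg.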

Compound 4, dose for half-maximal effect: 0.95 mg/kg
The estimate for compound 4 lay 1.1-fold (0.02 log units) above the measured number; measured number inside the range.
By their numbers in this assay, from the lowest: compounds 3 and 4 (each within the scatter of the next); then compound 1. At a limit, above all of these: compound 2.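

In this assay propanoyl in place of nitro on this aromatic carbon gives a 1.4-fold higher number from compound 3 to compound 4 (0.16 log units; within the scatter) and so leaves the dose needed unresolved from that of the nitro compound. Going by these compounds alone, this is the first direct comparison of two compounds that differ in only one place. It shows that nitro is not essential at this carbon, since a group with a carbonyl and no nitrogen serves within the scatter.

As far as these compounds go, whether an amine, a carboxylic acid or a chain longer than propanoyl would also serve here remains open. Nothing available explains why these two groups read alike.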